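The source may report more compounds than this note shows. Statements on the series, on what has been measured and on what is new or still open speak of the compounds shown alone.

The series shares a single amide core carrying a trifluoromethyl group and a hydroxyl on the carbon next to the carbonyl; what varies is the aromatic portion. Compound 1 `CC(O)(C(=O)Nc1ccc(S(=O)(=O)c2ccccc2)c(F)c1)C(F)(F)F` gives 1800 nM in a functional assay (Cavia porcellus) with sulfonylurea receptors; K-ATP channels (Homo sapiens) as the target; on this read-out lower numbers stand for stronger inhibition and higher numbers for weaker inhibition. Compound 2 `CC(O)(C(=O)Nc1ccc(S(=O)(=O)c2ccc(F)cc2)cc1)C(F)(F)F` gives 8600 nM in this assay, and compound 3 `CC(O)(C(=O)Nc1ccc(C#N)c(Sc2ccccc2)c1)C(F)(F)F` gives 8300 nM in this assay.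

On these three numbers compound 2 has the highest value. Its nearest neighbour is compound 3, whose number lies within the usual scatter of compound 2, so the two cannot be ordered. Compound 1 is the furthest away, with a number low enough to stand beyond the scatter, so compound 1 inhibits more strongly than compound 2.

The step to compound 4 `CC(O)(C(=O)Nc1ccc(S(=O)(=O)c2cccnc2)cc1)C(F)(F)F` starts from compound 2 and changes only the group on the sulfonyl sulfur: pyridin-3-yl in place of 4-fluorophenyl on a sulfonyl sulfur. For the measured compounds named here, no pair among the measured compounds isolates such a change, so there is no measured step on which to lean. The expectation is therefore that the step from compound 2 to compound 4 in this assay will be a 1.0-fold higher number from compound 2 to compound 4 (0.02 log units; within the scatter), that is, no change beyond the scatter. Compound 4 is accordingly expected to give about 9000 nM in this assay, within a range from 3000 nM to 30000 nM.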

Compound 4, half-maximal inhibitory concentration: 3500 nM
The estimate for compound 4 lay 2.6-fold (0.41 log units) above the measured number; measured number inside the range.
By their numbers in this assay, from the lowest: compounds 1 and 4 (each within the scatter of the next); then compounds 3 and 2 (each within the scatter of the next).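

In this assay the group on the sulfonyl sulfur proves able to shift the read-out (a 2.5-fold lower number from compound 2 to compound 4 (0.39 log units; beyond the scatter)), a modest step but one beyond the scatter, and the only pair shown that differs in one place. Compound 4 therefore inhibits more strongly than compound 2, showing that this position is not indifferent to exchanging one six-membered aromatic ring for another, here a carbon-only ring bearing fluorine for a ring with one hetero atom and one hydrogen-bond acceptor. No accompanying measurement bears on the reason for this step, so the result stands as an observation without an explanation.

The single step removes the fluorine and introduces the ring nitrogen together, so the compounds shown leave open how much each contributes, a question that a plain phenyl group on the sulfonyl sulfur of the compound 2 framework could help to settle. They also leave open whether the placement of the ring nitrogen matters, as pyridin-2-yl and pyridin-4-yl groups at the same sulfur would test, and whether a ring carrying an amine would extend the step.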